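From Bromo to Acetamido in a Narrow Series

This account rests on a few compounds, and the source may have more. Where it says the series, first, only, none or still open, it means among the compounds named here.

In a functional assay on SMMC-7721 cells (Homo sapiens) for cytotoxicity, read by MTT assay, with a stated time of 24 h (on this read-out higher numbers stand for weaker inhibition and lower numbers for stronger inhibition), compound 1 (`O=C1/C(=C/c2cccnc2)CN(S(=O)(=O)c2ccc(C(F)(F)F)cc2)C/C1=C\c1ccccc1F`) gives 7900 nM. Compound 2 (`O=C1/C(=C/c2cccnc2)CN(S(=O)(=O)c2ccc(F)cc2)C/C1=C\c1ccccc1F`) gives 9900 nM. Compound 3 (`O=C1/C(=C/c2cccnc2)CN(S(=O)(=O)c2ccc(Br)cc2)C/C1=C\c1ccccc1F`) gives 9100 nM, which stands within the scatter of both other values. Compound 4 (`CC(=O)Nc1ccc(S(=O)(=O)N2C/C(=C\c3cccnc3)C(=O)/C(=C/c3ccccc3F)C2)cc1`), not yet measured, carries acetamido in place of bromo on an aromatic carbon, para to a large group: acetamido in place of bromo on an aromatic carbon. Three measured exchanges at that place bear on this change: a 1.3-fold higher number from compound 1 to compound 2 (0.10 log units; within the scatter), a 1.2-fold higher number from compound 1 to compound 3 (0.06 log units; within the scatter) and a 1.1-fold lower number from compound 2 to compound 3 (0.04 log units; within the scatter). Acetamido itself appears in no measured compound, so this evidence is indirect. Resting on those small steps around compound 3 at 9100 nM, no step beyond the scatter is expected in this assay, and neither direction is favoured. The expected change is a 1.0-fold lower number from compound 3 to compound 4 (0.00 log units; within the scatter). For compound 4 the estimated value is 9000 nM, with an expected range from 4000 nM to 20000 nM.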

Compound 4, half-maximal inhibitory concentration: 10900 nM
Estimate against measurement, compound 4: 1.2-fold (0.08 log units) below; the range from low to high includes it.
By their numbers in this assay, from the lowest: compounds 1, 3, 2 and 4 (each within the scatter of the next).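

In this assay, for the compounds shown here, the earlier compounds varied this place, on an aromatic carbon para to a large group, only among fluoro, bromo and trifluoromethyl. Acetamido is a larger entrant with a hydrogen-bond donor and a hydrogen-bond acceptor, and it stays within the scatter of all three: against bromo (a 1.2-fold higher number from compound 3 to compound 4 (0.08 log units; within the scatter)), against fluoro (a 1.1-fold higher number from compound 2 to compound 4 (0.04 log units; within the scatter)) and against trifluoromethyl (a 1.4-fold higher number from compound 1 to compound 4 (0.14 log units; within the scatter)). So the four compounds show that this exchange, unlike the narrower ones before it, spans a clearly different kind of group and still leaves the number unresolved from the others, and no measurement at hand offers an explanation.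

As far as these compounds go, whether an amine, a carboxylic acid or a longer chain at this place would step beyond the scatter remains open. So does whether the same exchanges would behave alike on a different core or in another cell line.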